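A few compounds are considered here, and "the series" means these few. Any claim that something is new, unique, unknown or untested is made for them only; others in the source may bear on it.

Measured compounds:
compound 1, `CN1CCN(C(=O)/C=C/c2ccncc2-c2ccc3ccccc3c2)CC1`: 101%
compound 2, `CNC(=O)/C=C/c1ccncc1-c1ccc2ccccc2c1`: 101%
compound 3, `O=C(O)CCNC(=O)/C=C/c1ccncc1-c1ccc2ccccc2c1`: 91%

In an assay on a protein complex for inhibition of CDK8/Cyclin C (Homo sapiens), with a stated time of 1 h, tested at 10 uM (on this read-out lower numbers stand for less inhibition and higher numbers for more inhibition at the one concentration tested (going by the name of the read-out)), compound 2 gives 101%. On the numbers shown it stands level with compound 1, and the two together are the highest of the three numbers; its nearest neighbour is compound 1, no change at the digits printed from compound 1 to compound 2 (within the scatter), and its furthest is compound 3, a number 10 percentage points lower from compound 2 to compound 3 (within the scatter). All three measured compounds share the same core and differ only in what sits on the carbonyl carbon: compound 1 to compound 3 shows a number 10 percentage points lower from compound 1 to compound 3 (within the scatter). None of these steps moves beyond the scatter, so the amide end of the molecule has so far accepted every change offered without a visible effect.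

Compound 4, `CNC(=O)COc1ccncc1-c1ccc2ccccc2c1`, is not yet measured. It differs from compound 2 by (methylcarbamoyl)methoxy in place of 2-(methylcarbamoyl)ethenyl on an aromatic carbon. Among the compounds with values here, no measured step touches this part of the molecule, so the three steps speak only to the amide substituent and not to the linker. With nothing to anchor the new change, the estimate for compound 4 is expected to stay high but with a wide range, a number 16 percentage points lower from compound 2 to compound 4 (beyond the scatter); compound 4 is expected to give 85%, between 45% and 102%.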

Compound 4, a percentage reported as inhibition, at one concentration (the size of the read-out at that concentration, not a potency): 4%
For compound 4 the middle estimate is 81 percentage points above the measured one, outside the stated range (below it).
By their numbers in this assay, from the lowest: compound 4; then compounds 3, 1 and 2 (each within the scatter of the next).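

The amide end took every change within the scatter, but the link to the aromatic ring does not behave the same way: in this assay, putting (methylcarbamoyl)methoxy in place of 2-(methylcarbamoyl)ethenyl, on an aromatic carbon opposite the ring nitrogen and ortho to a large group, gives a number 97 percentage points lower from compound 2 to compound 4 (beyond the scatter). The step keeps the methylcarbamoyl end, and both groups hold 6 heavy atoms and no ring; the entering group has 1 double bond outside aromatic rings against 2, and 2 hydrogen-bond acceptors against 1. Among these compounds, then, the large step lies in the link rather than in the amide substituent, and no supporting data bear on why it is so large.

This single step cannot separate the loss of the double bond from the arrival of the oxygen, so a saturated chain or an amine nitrogen in the oxygen's place would be needed to tell the two apart. On these data alone, it also remains open whether a link other than the ethenyl one could keep the read-out high, and whether 4-methylpiperazin-1-yl on the carbonyl carbon would behave any differently with the methoxy link.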